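Fluoro removal on the aryl ring of compound 2

This account rests on a few compounds, and the source may have more. Where it says the series, first, only, none or still open, it means among the compounds named here.

Values in an assay on BAF cells for inhibition of ribosomal protein S6 kinase alpha-2 (Mus musculus); a higher number here means a weaker inhibitor, a lower number a stronger inhibitor:
compound 1 `COc1cccc(F)c1-c1cccc2nc(N)oc12`: > 20000 nM, a limit of the assay, not a number
compound 2 `COc1cc(Nc2nc3cccc(-c4c(F)cccc4OC)c3o2)cc(OC)c1OC`: 2600 nM
compound 3 `COc1cc(Nc2nc3cccc(-c4c(F)cccc4OC)c3o2)cc(OC)c1`: 17200 nM

Compound 2 holds the lower of the two numeric values; its nearest neighbour is compound 3, reached by a 6.6-fold higher number from compound 2 to compound 3 (0.82 log units; beyond the scatter), hydrogen in place of methoxy on an aromatic carbon. Compound 1 sits at a limit only, (the limit of > 20000 nM in this assay, at which 1 of the 3 values shown sits).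

Compound 4 `COc1ccccc1-c1cccc2nc(Nc3cc(OC)c(OC)c(OC)c3)oc12` differs from compound 2 by hydrogen in place of fluoro on an aromatic carbon. Going by the values given here, no measured step concerns a fluoro or this position; the single measured step, a 6.6-fold higher number from compound 2 to compound 3 (0.82 log units; beyond the scatter), removes a methoxy and so does not bear directly on the change. With nothing to anchor it, the expectation for this assay is a small step at most, direction open, with a slight weakening thought somewhat more likely than a gain. Compound 4 is therefore estimated at 4000 nM, range 1300 nM to 12000 nM, an expected step of a 1.5-fold higher number from compound 2 to compound 4 (0.19 log units; within the scatter).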

Compound 4, half-maximal inhibitory concentration: 5700 nM
Estimate against measurement, compound 4: 1.4-fold (0.15 log units) below; measured number inside the range.
By their numbers in this assay, from the lowest: compound 2; then compound 4; then compound 3. At a limit, above all of these: compound 1.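

Hydrogen in place of the fluoro, 2-fluoro-6-methoxyphenyl to 2-methoxyphenyl, gives a 2.2-fold higher number from compound 2 to compound 4 (0.34 log units; beyond the scatter) in this assay, the only measured change on this ring. The fluoro therefore contributes modestly to the lower number of compound 2, and compound 4 still gives a measurable value without it. Nothing at hand accounts for the step.

On these data alone, whether chloro, methyl or a nitrile in place of the fluoro would match compound 2 remains open. So does whether the same step would appear with the aryl amine of compound 3.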